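One Substituent Change Carried From One Core to Another

The compounds below may be only part of what the source reports. "The series", "measured", "known", "first", "only" and "open" are said of these compounds alone.

Of the compounds shown here, three have been measured in a functional assay on thoracic aorta (Rattus norvegicus) for inhibition; on this read-out lower numbers stand for an effect already at smaller amounts and higher numbers for an effect only at larger amounts of compound. Compound 1 `CC1(C)CC(NC(=O)Nc2ccc(C#N)cc2)c2cc(NS(C)(=O)=O)ccc2O1` gives 19800 nM, compound 2 `CC1(C)CC(NC(=O)Nc2cccc(Cl)c2)c2cc(NS(C)(=O)=O)ccc2O1` gives 15200 nM, and compound 3 `CCS(=O)(=O)Nc1ccc2c(c1)C(NC(=S)Nc1ccc(C#N)cc1)CC(C)(C)O2` gives 12000 nM. Compound 1 and compound 2 share a core and differ in one place: 3-chlorophenyl in place of 4-cyanophenyl on an amide-type nitrogen. That change produced a 1.3-fold lower number from compound 1 to compound 2 (0.11 log units; within the scatter).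

Compound 4 `CCS(=O)(=O)Nc1ccc2c(c1)C(NC(=S)Nc1cccc(Cl)c1)CC(C)(C)O2` is built on the core of compound 3 and is not yet measured. It differs from compound 3 in the same way: 3-chlorophenyl in place of 4-cyanophenyl on an amide-type nitrogen. The two cores are not identical, and the difference between them is not broken down here. The surroundings of the change also differ: in compound 1 the other neighbour of the amide-type nitrogen is a carbonyl carbon, while in compound 3 it is a thiocarbonyl carbon, so the two changes are the same kind of change rather than the same.

Beside a 1.3-fold lower number from compound 1 to compound 2 (0.11 log units; within the scatter), the expected step for compound 4 is a 1.3-fold lower number from compound 3 to compound 4 (0.10 log units; within the scatter), resting on compound 3 at 12000 nM and on the same kind of change. Compound 4 is therefore estimated at 9500 nM, within a range from 4500 nM to 20000 nM.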

Compound 4, half-maximal effective concentration: 9800 nM
Compound 4: middle estimate off by 1.0-fold (0.01 log units), on the low side; the range from low to high includes it.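

On the second core, 3-chlorophenyl in place of 4-cyanophenyl on an amide-type nitrogen gives a 1.2-fold lower number from compound 3 to compound 4 (0.09 log units; within the scatter) in this assay. Set beside the same change on the first core, the two steps agree: the same change on two cores in this assay, a 1.3-fold lower number (0.11 log units; within the scatter) from compound 1 to compound 2 and a 1.2-fold lower number (0.09 log units; within the scatter) from compound 3 to compound 4, 1.1-fold (0.03 log units) apart, within the scatter of two such steps. This shows that, on these two cores, the change makes no difference that can be told from ordinary repeat scatter; it does not show that the change has a real effect that carries over, since neither step is large enough to stand out from that scatter, and two cores cannot speak for the whole series.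

The compounds shown leave open how an amine, a carboxylic acid or a longer alkyl chain in place of these two aryl groups on the amide-type nitrogen would read in this assay. They also leave open whether a step large enough to stand clear of the scatter would carry from one core to the other as closely as this one does.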